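This account rests on a few compounds, and the source may have more. Where it says the series, first, only, none or still open, it means among the compounds named here.

Among the compounds with values here, in an ADME assay on CHO cells (Cricetulus griseus) for cytotoxicity, read by MTT assay, with a stated time of 72 h (a higher number here means that more compound is tolerated, a lower number that less compound is tolerated), compound 1 `CCOC(=O)c1c(-c2ccccc2)oc2ccc(OCCCN3C(=O)C(=O)c4ccccc43)cc12` gives 256000 nM and compound 2 `CCOC(=O)c1c(-c2ccc(F)cc2)oc2ccc(OCCCN3C(=O)C(=O)c4ccccc43)cc12` gives 256000 nM, so compound 1 stands level with its only measured neighbour at the digits reported. Compound 3 `CCOC(=O)c1c(-c2ccccc2)oc2ccc(OCCCN3C(=O)C(=O)c4cc(OC)ccc43)cc12`, still unmeasured in this assay, keeps the core of compound 1 and differs from it in one place: methoxy in place of hydrogen on an aromatic carbon. This is methoxy in place of hydrogen on an aromatic carbon, on a ring that is part of a fused or bridged system of two rings.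

Within the data shown here, only one measured step bears on this change, and only loosely: no change at the digits printed from compound 1 to compound 2 (within the scatter), with fluoro in place of hydrogen on an aromatic carbon. Among the measured compounds shown here, that step involves a different group at a different place, and no measured compound here carries a methoxy, so it is a weak guide. Even so, it gives no reason to expect a real shift in this assay. The expected result is a 1.1-fold lower number from compound 1 to compound 3 (0.05 log units; within the scatter), which is estimated to stay within the scatter and has no firm direction. Compound 3 is estimated at 230000 nM, with an expected range from 120000 nM to 450000 nM.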

Compound 3, half-maximal cytotoxic concentration: 512000 nM
The estimate for compound 3 lay 2.2-fold (0.35 log units) below the measured number; the measured number lies above the stated range.
By their numbers in this assay, from the lowest: compounds 1, 2 and 3 (each within the scatter of the next).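

In this assay, within the data shown here, the methoxy group on this six-membered aromatic ring of carbon only, part of a fused or bridged system of two rings, gives a 2.0-fold higher number from compound 1 to compound 3 (0.30 log units; within the scatter), the first reading at this place in the molecule. The earlier step, no change at the digits printed from compound 1 to compound 2 (within the scatter), concerned fluoro at a different place and so said nothing directly about this ring; the new step shows that, in this assay, compound 3 cannot be separated from compound 1 at this position, even though methoxy brings in two heavy atoms and a hydrogen-bond acceptor where there was only a hydrogen. No measurement shown here accounts for the size of this step or tells what lies behind it.

The compounds shown leave open whether an amine, a carboxylic acid or a longer chain such as ethoxy at this same place would move the number beyond the scatter. They also leave open whether methoxy would read the same at another place on this ring or elsewhere on the shared core.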